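Swapping a bromine for methoxy on the aniline ring

The source may hold more compounds than are shown below. What is called first, only, known or untested is meant among the compounds shown, and "the series" means these compounds.

Of the compounds shown here, three sharing one core have been measured in a functional assay on MCF7 cells (Homo sapiens) for antiproliferative activity, read by MTT assay, with a stated time of 24 h; on this read-out lower numbers stand for stronger inhibition and higher numbers for weaker inhibition. Compound 1 `CNC(=O)c1ccccc1Oc1nc(Nc2cccc(Br)c2)ncc1Br` gives 42500 nM. Compound 2 `CNC(=O)c1ccccc1Oc1nc(Nc2ccc(C)cc2C)ncc1Br` gives 44700 nM, and compound 3 `CNC(=O)c1ccccc1Oc1nc(Nc2cccc(C(F)(F)F)c2)ncc1Br` gives 57800 nM. The step of a 1.1-fold higher number from compound 1 to compound 2 (0.02 log units; within the scatter) and the step of a 1.4-fold higher number from compound 1 to compound 3 (0.13 log units; within the scatter) both stay inside the usual scatter, so the three values of compound 1, compound 2 and compound 3 sit together rather than apart.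

Compound 4 `CNC(=O)c1ccccc1Oc1nc(Nc2cccc(OC)c2)ncc1Br` differs from compound 1 in one place: methoxy in place of bromo on an aromatic carbon. Among the compounds with values here, no measured pair shows exactly this exchange. The closest comparison is compound 1 to compound 3, where the bromo on that ring was replaced by another group and the value barely moved, and compound 1 to compound 2, where a different substitution pattern on the same ring likewise left the value almost unchanged. On that basis the step of a 1.1-fold higher number from compound 1 to compound 4 (0.02 log units; within the scatter) is expected to stay within the scatter, with no clear direction. Compound 4 is therefore estimated at 45000 nM, with a likely range from 20000 nM to 100000 nM.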

Compound 4, half-maximal inhibitory concentration: 18200 nM
For compound 4 the middle estimate is 2.5-fold (0.39 log units) above the measured one; measured number outside the range, below it.
By their numbers in this assay, from the lowest: compound 4; then compounds 1, 2 and 3 (each within the scatter of the next).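

In this assay, within the data shown here, methoxy is the first group on this ring to set a compound apart: a 2.3-fold lower number from compound 1 to compound 4 (0.37 log units; beyond the scatter) and a 3.2-fold lower number from compound 3 to compound 4 (0.50 log units; beyond the scatter) both lie beyond the scatter, although compound 1 and compound 3, with bromo and trifluoromethyl at this place, sit within the scatter of each other. The other listed comparison points the same way, with a 2.5-fold lower number from compound 2 to compound 4 (0.39 log units; beyond the scatter) also beyond the scatter, so the choice of group on this ring can change the value, though only modestly so far. Nothing available explains why methoxy lowers the number.

As far as these compounds go, it remains open whether the shift depends on methoxy as a whole or on its oxygen alone. A hydroxy group, an ethoxy chain or an amine at this place could show whether the number falls further or returns towards that of compound 1.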